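Replacing the ether linker with a direct aryl group on the core

The compounds below may be only part of what the source reports. "The series", "measured", "known", "first", "only" and "open" are said of these compounds alone.

Compound 3 `Cc1nn(-c2ncnc3nc[nH]c23)c2c1C(OCCc1ccccc1)CC(=O)N2` gives 3 nM in a functional assay on HEK293 cells for agonist activity at G-protein coupled receptor 39 (Homo sapiens), read by scintillation proximity assay and inositol phosphate accumulation, with a stated time of 75 min, in the presence of a further agent that is not named here (a higher number here means that more compound is needed for the effect, a lower number that less compound is needed), the lowest number among the three measured compounds, although its step from compound 1 `Cc1noc(C)c1COC1CC(=O)Nc2c1c(C)nn2-c1ncnc2nc[nH]c12`, which gives 5 nM, is within the scatter. Compound 2 `Cc1nn(-c2ncnc3nc[nH]c23)c2c1C(OCCn1nccc1C)CC(=O)N2` gives 10 nM, and a 3.3-fold lower number from compound 2 to compound 3 (0.52 log units; beyond the scatter). Compound 4 `Cc1nn(-c2ncnc3nc[nH]c23)c2c1C(c1ccc(F)cc1Cl)CC(=O)N2` differs from compound 3 by 2-chloro-4-fluorophenyl in place of phenethyloxy on a saturated ring carbon. The measured steps, a 2.0-fold higher number from compound 1 to compound 2 (0.30 log units; within the scatter) and a 1.7-fold lower number from compound 1 to compound 3 (0.22 log units; within the scatter), all vary only the group beyond the oxygen and keep the ether link; none removes it, so they bear on this change only loosely. Among the compounds with values here, the data give no precedent for the new substituent, so the expected step is uncertain, and compound 4 is estimated at 12 nM, with a range from 2 nM to 70 nM, meaning a 4.0-fold higher number from compound 3 to compound 4 (0.60 log units; beyond the scatter).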

Compound 4, half-maximal effective concentration: 9 nM
The estimate for compound 4 lay 1.3-fold (0.12 log units) above the measured number; the measured number falls inside the stated range.
By their numbers in this assay, from the lowest: compounds 3, 1, 4 and 2 (each within the scatter of the next, the first and the last beyond it).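

Direct attachment of 2-chloro-4-fluorophenyl at the saturated ring carbon shows that the ether link is not needed for activity in this assay at this position, although the change from phenethyloxy costs something (a 3.0-fold higher number from compound 3 to compound 4 (0.48 log units; beyond the scatter)). Against the other two ether compounds, the direct aryl group shows no separation (a 1.1-fold lower number from compound 2 to compound 4 (0.05 log units; within the scatter); a 1.8-fold higher number from compound 1 to compound 4 (0.26 log units; within the scatter)). No evidence here accounts for these steps. The compounds shown leave open whether the chlorine or the fluorine contributes to this result, and how an amine or a carboxylic acid would fare on this carbon.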